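The compounds below may be only part of what the source reports. "The series", "measured", "known", "first", "only" and "open" are said of these compounds alone.

Measured so far:
compound 1, `CCOc1ccc(NC(=O)c2cccc(/C=C3\CC(=O)N(Cc4ccccc4)C3=O)c2)cc1` — in an ADME assay on NCM460 cells (Homo sapiens) for cytotoxicity, read by MTT assay, with a stated time of 72 h (on this read-out higher numbers stand for weaker inhibition and lower numbers for stronger inhibition), compound 1 gives > 100000 nM
compound 2, `Cc1ccc(NC(=O)c2cccc(/C=C3\CC(=O)N(c4ccccc4)C3=O)c2)cc1C` — in this assay compound 2 gives > 100000 nM

Both readings are limits of the assay, not numbers. Compound 2 sits at the limit of > 100000 nM in this assay, at which 2 of the 2 values shown sit; its value is a limit and says only that no inhibition was reached within the tested range. Compound 1 likewise sits at a limit. Among the compounds with values here, the two compounds differ in more than one place, so no single step between them can be set out; what they show together is that neither reaches a measurable value.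

Compound 3, `CCc1ccc(NC(=O)c2cccc(/C=C3\CC(=O)N(c4ccccc4)C3=O)c2)cc1`, is the next entry. It is an isomer of compound 2: 4-ethylphenyl in place of 3,4-dimethylphenyl on an amide-type nitrogen. Within the data shown here, no measured step speaks to this kind of change, and with both known values sitting at the limit no direction can be drawn from them. The expectation is a step of a number no higher from compound 2 to compound 3 (the limit leaves the size open), that is, none beyond the usual scatter. Compound 3 is therefore expected to give about 100000 nM, with a range from 40000 nM to 200000 nM, and most likely to return another limit rather than a number.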

Compound 3, half-maximal inhibitory concentration: > 100000 nM
Compound 3: only a limit was reported; the forecaster's own chance of this, stated with the estimate: 85%; the middle value lies on the limit itself.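

In this assay compound 3 gives > 100000 nM as a limit of the assay. Compound 2 also sits at a limit, so no step can be read between compound 2 and compound 3. These compounds leave open whether 3,4-dimethylphenyl and 4-ethylphenyl on the amide-type nitrogen differ at all in this assay and how far any of the compounds lies beyond the limit.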